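Fluoro in place of hydrogen on compound 2

The source may hold more compounds than are shown below. What is called first, only, known or untested is meant among the compounds shown, and "the series" means these compounds.

Compound 1 `C/C(COc1cccc2ccccc12)=N\O`: > 50000 nM
Compound 2 `O/N=C(\COc1cccc2ccccc12)c1ccccc1`: > 50000 nM

Both results come from an ADME assay on Jurkat cells (Homo sapiens) for cytotoxicity, read by MTT assay; a lower number here means a stronger inhibitor, a higher number a weaker inhibitor. In this assay compound 1 gives > 50000 nM, which is a limit of the assay and not a number. Compound 2 gives > 50000 nM, which is likewise a limit and not a number. Compound 2 therefore has no measured number of its own, and it shares its position with compound 1: the limit of > 50000 nM in this assay, at which 2 of the 2 values shown sit.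

Compound 3 `O/N=C(\COc1cccc2ccccc12)c1ccc(F)cc1` differs from compound 2 in one place: fluoro in place of hydrogen on an aromatic carbon. In words, this is fluoro in place of hydrogen on an aromatic carbon, turning phenyl into 4-fluorophenyl. Within the data shown here, no measured pair shows what such a change does in this assay. The expectation can rest only on compound 2, whose > 50000 nM is again just a limit. No step beyond the scatter is expected, in either direction. The expected move is a number no higher from compound 2 to compound 3 (the limit leaves the size open). For compound 3 the estimate is 50000 nM, with an expected range from 25000 nM to 100000 nM.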

Compound 3, half-maximal inhibitory concentration: > 50000 nM
Compound 3 was reported as a limit; the forecaster's own chance of this, stated with the estimate: 80%; the middle value sits exactly at the limit.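

In this assay compound 3 gives > 50000 nM as a limit of the assay and not a number. Compound 2 also stands at a limit, so no step can be read between compound 2 and compound 3, and all the compounds shown share one position: the limit of > 50000 nM in this assay, at which 3 of the 3 values shown sit. The compounds shown leave open what size of change, if any, fluoro in place of hydrogen on an aromatic carbon brings in this assay.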